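A few compounds are considered here, and "the series" means these few. Any claim that something is new, unique, unknown or untested is made for them only; others in the source may bear on it.

Measured in a functional assay on Caco-2 cells (Homo sapiens) for inhibition, read by MTT assay, with a stated time of 48 h, tested at 10 uM; a lower number here means less inhibition of growth, a higher number more inhibition of growth at the concentration tested:
- compound 1 `CCN(CC)Cc1c(O)c([C@H]2CCN(C)C[C@H]2O)c2oc(C)cc(=O)c2c1O`: 17%
- compound 2 `Cc1oc2c([C@H]3CCN(C)C[C@H]3O)c(O)cc(O)c2c(=O)c1C(O)c1cccc(Cl)c1`: 4%

Compound 2, at 4%, holds the lower of the two numbers, and its gap to compound 1 lies beyond the usual scatter. Among the measured compounds shown here, these two compounds do not differ in one place, so no measured step shows what a single change does here. Compound 3 `COc1ccc(C(O)c2c(C)oc3c([C@H]4CCN(C)C[C@H]4O)c(O)cc(O)c3c2=O)cc1Br` has 3-bromo-4-methoxyphenyl in place of 3-chlorophenyl on a saturated chain carbon bound to an aromatic carbon and an oxygen on a saturated carbon. The expected result in this assay is a number 4 percentage points higher from compound 2 to compound 3 (within the scatter), a small rise that stays within the scatter. For compound 3 the estimated value is 8%, with an expected range from 0% to 22%.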

Compound 3, percent growth inhibition at one concentration: 0%
Estimate against measurement, compound 3: 8 percentage points above, within the range that was stated.
By their numbers in this assay, from the lowest: compounds 3 and 2 (each within the scatter of the next); then compound 1.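

In this assay, among the compounds shown here, 3-bromo-4-methoxyphenyl in place of 3-chlorophenyl on a saturated chain carbon bound to an aromatic carbon and an oxygen on a saturated carbon gives a number 4 percentage points lower from compound 2 to compound 3 (within the scatter), the first single change that can be read here. At this position, the two groups cannot be told apart in this test, even though the entering group has bromine instead of chlorine and adds a methoxy group. Nothing available explains this result.

From the compounds shown here alone, whether an amine or a carboxylic acid on the phenyl ring would change the growth inhibition remains open. So does the role of the hydroxy group on the chain carbon, which compound 2 and compound 3 share.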